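The source may hold more compounds than are shown below. What is called first, only, known or untested is meant among the compounds shown, and "the series" means these compounds.

Compound 1 `CC1=C(C(=O)OC(C)(C)C)C(c2cccs2)NC(=O)N1` gives 38% in an assay on membranes from HEK293 cells for displacement of a labelled ligand from adenosine receptor A2b (Homo sapiens), read by scintillation counting, with a stated time of 30 min, tested at 1 uM; a higher number here means more inhibition at the concentration tested (going by the name of the read-out), a lower number less inhibition. Within the data shown here, compound 2 `CCSC(=O)C1=C(C)NC(=O)NC1c1cccs1` gives 1% in this assay and stands as the lower of the two numbers known so far. Among the measured compounds shown here, the one measured step, a number 37 percentage points lower from compound 1 to compound 2 (beyond the scatter), came with ethylsulfanyl in place of tert-butoxy on a carbonyl carbon. Compound 3 `CC1=C(C(=O)OC2CCCCC2)C(c2cccs2)NC(=O)N1` differs from compound 2 by cyclohexyloxy in place of ethylsulfanyl on a carbonyl carbon, which undoes that kind of change, so a step upward beyond the scatter is expected in this assay, toward the number of compound 1. For compound 3 the expected value is 35%, within 10% to 60%, an expected step of a number 34 percentage points higher from compound 2 to compound 3 (beyond the scatter).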

Compound 3, a percentage reported as inhibition, at one concentration (the size of the read-out at that concentration, not a potency): 3%
The estimate for compound 3 lay 32 percentage points above the measured number; the whole stated range lies above it.
By their numbers in this assay, from the lowest: compounds 2 and 3 (each within the scatter of the next); then compound 1.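

In this assay the oxygen on the carbonyl carbon does not by itself restore the number of compound 1: a number 2 percentage points higher from compound 2 to compound 3 (within the scatter), so cyclohexyloxy and ethylsulfanyl cannot be told apart here. The change on that oxygen alone also matters, since cyclohexyl in place of tert-butyl gives a number 35 percentage points lower from compound 1 to compound 3 (beyond the scatter), so the large step seen with ethylsulfanyl need not be tied to sulfur. Nothing available explains this difference between tert-butyl and cyclohexyl. As far as these compounds go, whether a methyl or isopropyl group on that oxygen, or an amine on the carbonyl carbon, would stand with compound 1 or with compound 2 and compound 3 remains open.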